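Methoxy on the urea nitrogen: little change expected

A few compounds are considered here, and "the series" means these few. Any claim that something is new, unique, unknown or untested is made for them only; others in the source may bear on it.

Measured compounds in an assay on IM-9 cells for displacement of a labelled ligand from Substance-P receptor (Homo sapiens), read by scintillation counting, with a stated time of 30 min; a higher number here means a weaker inhibitor, a lower number a stronger inhibitor:
- compound 1 `CC(=O)N1CCC(C(=O)N2CC[C@H](C(=O)N(C)Cc3cc(C(F)(F)F)cc(C(F)(F)F)c3)[C@@H](c3ccc(F)cc3C)C2)CC1` gives 0.047 nM
- compound 2 `CNC(=O)N1CC[C@H](C(=O)N(C)Cc2cc(C(F)(F)F)cc(C(F)(F)F)c2)[C@@H](c2ccc(F)cc2C)C1` gives 0.048 nM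
- compound 3 `Cc1cc(F)ccc1[C@H]1CN(C(N)=O)CC[C@@H]1C(=O)N(C)Cc1cc(C(F)(F)F)cc(C(F)(F)F)c1` gives 0.035 nM

Compound 3 shows the lowest of the three numbers, yet it cannot be set apart from the others: a 1.3-fold lower number from compound 1 to compound 3 (0.13 log units; within the scatter) and a 1.4-fold lower number from compound 2 to compound 3 (0.14 log units; within the scatter) both lie within the scatter, as does a 1.0-fold higher number from compound 1 to compound 2 (0.01 log units; within the scatter). All three compounds share one core and differ only in the group carried on the carbonyl carbon of the urea, and none of those exchanges moved this assay beyond the scatter.

Compound 4 `CONC(=O)N1CC[C@H](C(=O)N(C)Cc2cc(C(F)(F)F)cc(C(F)(F)F)c2)[C@@H](c2ccc(F)cc2C)C1` carries the change (methoxy in place of hydrogen on an amide-type nitrogen). This again touches only the outer end of the urea, the same region where the three measured steps were all flat. The expected step from compound 3 to compound 4 is therefore a 1.3-fold higher number from compound 3 to compound 4 (0.11 log units; within the scatter), no change beyond the scatter. Compound 4 is estimated at 0.045 nM, with a likely range from 0.018 nM to 0.11 nM.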

Compound 4, half-maximal inhibitory concentration: 0.073 nM
Estimate against measurement, compound 4: 1.6-fold (0.21 log units) below, and the stated range covers the measured number.
By their numbers in this assay, from the lowest: compounds 3, 1, 2 and 4 (each within the scatter of the next, the first and the last beyond it).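

Methoxy on the amide-type nitrogen gives the first step at the outer end of the urea that passes the scatter in this assay: the modest change is a 2.1-fold higher number from compound 3 to compound 4 (0.32 log units; beyond the scatter) and it is seen only against the unsubstituted urea. Against the other two compounds the same end shows no separation, with a 1.5-fold higher number from compound 2 to compound 4 (0.18 log units; within the scatter) and a 1.6-fold higher number from compound 1 to compound 4 (0.19 log units; within the scatter) both read as within the scatter, so this position accepts methoxy with little effect on the number and the earlier flat picture is only slightly qualified. No measurement shown here gives a reason for the one step beyond the scatter.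

As far as these compounds go, whether hydroxy or ethoxy on this nitrogen would fall with methoxy or with hydrogen remains open. So does the outcome of a dimethylamino group in place of the methoxyamino group on the carbonyl carbon.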